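The compounds below may be only part of what the source reports. "The series", "measured", "known", "first", "only" and "open" are said of these compounds alone.

Compound 1 `COc1cc(C)nc(OC)c1NC(=O)N(Cc1ccc(Oc2ccc(F)cc2)cc1)C1CCCCCC1` gives 33 nM in an assay for inhibition of acyl-CoA:cholesterol acyltransferase (Oryctolagus cuniculus), using microsomes (a lower number here means a stronger inhibitor, a higher number a weaker inhibitor), compound 2 `Cc1cc(Cl)c(NC(=O)N(Cc2ccc(Oc3ccc(F)cc3)cc2)C2CCCCCC2)c(Cl)n1` gives 14 nM, and compound 3 `CSc1cc(C)nc(Cl)c1NC(=O)N(Cc1ccc(Oc2ccc(F)cc2)cc1)C1CCCCCC1` gives 46 nM, the highest of the three numbers, within the scatter of compound 1 yet clearly apart from compound 2. Compound 4 `CSc1cc(C)nc(S(C)(=O)=O)c1NC(=O)N(Cc1ccc(Oc2ccc(F)cc2)cc1)C1CCCCCC1` differs from compound 3 by methylsulfonyl in place of chloro on an aromatic carbon, next to the ring nitrogen. Within the data shown here, no measured step swaps chloro for methylsulfonyl directly. The nearest guide is a 3.3-fold higher number from compound 2 to compound 3 (0.52 log units; beyond the scatter), where a sulfur-bearing group replaced chloro and weakened inhibition, while a 2.4-fold lower number from compound 1 to compound 2 (0.37 log units; beyond the scatter) shows chloro pairs beating methoxy pairs, so a further modest rise in this assay is expected. Compound 4 is therefore estimated at 130 nM, between 40 nM and 450 nM, which means an expected 2.8-fold higher number from compound 3 to compound 4 (0.45 log units; beyond the scatter).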

Compound 4, half-maximal inhibitory concentration: 78 nM
For compound 4 the middle estimate is 1.7-fold (0.22 log units) above the measured one; low and high end bracket the measured number.
By their numbers in this assay, from the lowest: compound 2; then compounds 1, 3 and 4 (each within the scatter of the next, the first and the last beyond it).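

Putting methylsulfonyl in place of chloro, on the aromatic carbon next to the ring nitrogen, gives a 1.7-fold higher number from compound 3 to compound 4 (0.23 log units; within the scatter) in this assay and so leaves the two compounds indistinguishable. Among these compounds, this position therefore takes methylsulfonyl as readily as chloro, something the earlier compounds could not show. Nothing here explains why the larger group is accepted. Still open, going by these compounds, is how an amine, a carboxylic acid or a longer chain such as propylsulfonyl would behave at this same position.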